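This account rests on a few compounds, and the source may have more. Where it says the series, first, only, none or still open, it means among the compounds named here.

Compound 1 `COc1cc2c(cc1OC)CN(S(=O)(=O)c1ccc(-n3cc(COc4ccc([N+](=O)[O-])cc4)nn3)cc1)CC2` gives in a functional assay on A549 cells (Homo sapiens) for cytotoxicity, read by MTT assay, with a stated time of 48 h; a lower number here means a stronger inhibitor, a higher number a weaker inhibitor > 50 ug/mL, which is a limit of the assay and not a number. Compound 2 `COc1cc2c(cc1OC)CN(S(=O)(=O)c1ccc(-n3cc(COc4ccc(C)cc4)nn3)cc1)CC2` gives in this assay > 50 ug/mL, again a limit. The step that the two limits leave unreadable from compound 1 to compound 2 is therefore unreadable, since both values sit at the limit of > 50 ug/mL in this assay, at which 2 of the 2 values shown sit. Compound 3 `COc1cc2c(cc1OC)CN(S(=O)(=O)c1ccc(-n3cc(COc4ccccc4)nn3)cc1)CC2` differs from compound 2 by hydrogen in place of methyl on an aromatic carbon. Within the data shown here, no measured step bears on this change, and with both measured values resting at the limit no step beyond the scatter is expected; the expected step is a step that the limit leaves unreadable from compound 2 to compound 3. Compound 3 is expected to give about 70 ug/mL, within 25 ug/mL to 200 ug/mL, most likely reported again as a limit.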

Compound 3, half-maximal inhibitory concentration: > 50 ug/mL
Compound 3 ended at the assay's limit; the forecaster's own chance of this, stated with the estimate: 85%; the middle value is on the limit's open side.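

No step can be read among compound 1, compound 2 and compound 3 in this assay, where all three values are limits: the limit of > 50 ug/mL in this assay, at which 3 of the 3 values shown sit.

On these data alone, whether nitro, methyl or hydrogen on that aromatic carbon makes any difference in this assay stays open.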